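Bromomethyl for prop-1-en-1-yl on an amide carbonyl

The source may report more compounds than this note shows. Statements on the series, on what has been measured and on what is new or still open speak of the compounds shown alone.

Measured in a functional assay on MGC-803 cells (Homo sapiens) for inhibition, read by MTT assay, with a stated time of 48 h (a higher number here means a weaker inhibitor, a lower number a stronger inhibitor), so far
- compound 1 `COc1ccc(CN(C(=O)CN=[N+]=[N-])c2cc(OC)c(OC)c(OC)c2)cc1O` gives 120 nM
- compound 2 `C/C=C/C(=O)N(Cc1ccc(OC)c(O)c1)c1cc(OC)c(OC)c(OC)c1` gives 27 nM

Of the two measured compounds, compound 2 has the lowest number, at 27 nM, and is the stronger inhibitor in this assay. Compound 3 `COc1ccc(CN(C(=O)CBr)c2cc(OC)c(OC)c(OC)c2)cc1O` has not yet been measured. It differs from compound 2 by one change (bromomethyl in place of prop-1-en-1-yl on a carbonyl carbon): bromomethyl in place of prop-1-en-1-yl on a carbonyl carbon.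

For the measured compounds named here, one measured step bears on this place: a 4.4-fold lower number from compound 1 to compound 2 (0.65 log units; beyond the scatter), with prop-1-en-1-yl in place of azidomethyl on the same carbonyl carbon. Going by the values given here, no bromomethyl compound has been measured, so only this modest step guides the expectation. Compound 1, which also carries a substituted methyl there, gives 120 nM, so a modest rise in the number is expected. The estimated step is a 2.2-fold higher number from compound 2 to compound 3 (0.35 log units; beyond the scatter), though its range still reaches the scatter. For compound 3 the estimated value is 60 nM, with an expected range of 15 nM to 240 nM.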

Compound 3, half-maximal inhibitory concentration: 140 nM
Beside the measured number, compound 3's estimate is 2.3-fold (0.37 log units) below it; the measured number falls inside the stated range.
By their numbers in this assay, from the lowest: compound 2; then compounds 1 and 3 (each within the scatter of the next).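

In this assay this place on the carbonyl carbon now has a second substituted methyl group to set against prop-1-en-1-yl, and the change to bromomethyl brings a 5.2-fold higher number from compound 2 to compound 3 (0.71 log units; beyond the scatter) as its result. Bromo and azido on the saturated chain carbon bound to a carbonyl carbon cannot be told apart, with a 1.2-fold higher number from compound 1 to compound 3 (0.07 log units; within the scatter) between them, so compound 2 stands alone among the three and the two substituted methyl compounds stand together. Nothing given here accounts for this difference between prop-1-en-1-yl and the two substituted methyl groups.

The compounds shown leave open whether the lower number of compound 2 goes with the double bond of prop-1-en-1-yl or with its chain, which a saturated propyl chain on the same carbonyl carbon would separate. They also leave open how a plain methyl or an aminomethyl group there would compare with bromomethyl and azidomethyl.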